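Shifting a Methyl Group on the Amide Nitrogen Substituent

A few compounds are considered here, and "the series" means these few. Any claim that something is new, unique, unknown or untested is made for them only; others in the source may bear on it.

Three compounds share one core and differ only in the group attached to an amide-type nitrogen. Compound 1 `COc1ccc2c(=O)c(/C=C/C(=O)NCc3ccccc3F)coc2c1` carries a 2-fluorobenzyl there. In a functional assay on L02 cells (Homo sapiens) for inhibition, read by MTT assay, with a stated time of 48 h (a higher number here means a weaker inhibitor, a lower number a stronger inhibitor), compound 1 reaches only the limit of the measurement, > 200000 nM. Compound 2 `COc1cccc(NC(=O)/C=C/c2coc3cc(OC)ccc3c2=O)c1` bears a 3-methoxyphenyl instead, and in this assay compound 2 likewise gives only a limit, > 200000 nM. Compound 3 `COc1ccc2c(=O)c(/C=C/C(=O)Nc3cccc(C)c3)coc2c1` carries a 3-methylphenyl; in this assay compound 3 too gives only a limit, > 200000 nM. Because (the limit of > 200000 nM in this assay, at which 3 of the 3 values shown sit), none of the steps between these three can be read: a step that the two limits leave unreadable from compound 1 to compound 2, a step that the two limits leave unreadable from compound 1 to compound 3 and a step that the two limits leave unreadable from compound 2 to compound 3 all remain without a size. Compound 3 therefore stands at the limit together with the other two, with no number to place it.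

Compound 4 `COc1ccc2c(=O)c(/C=C/C(=O)Nc3ccccc3C)coc2c1` differs from compound 3 as follows: 2-methylphenyl in place of 3-methylphenyl on an amide-type nitrogen. For the measured compounds named here, no measured step shows any compound leaving the limit, so nothing points to a readable change. The expected step from compound 3 to compound 4 is a number no higher from compound 3 to compound 4 (the limit leaves the size open), meaning a result that stays at the limit. Compound 4 is thus estimated to give about 200000 nM in this assay, with a range from 50000 nM to 200000 nM.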

Compound 4, half-maximal inhibitory concentration: > 200000 nM
Compound 4: a limit, no number (the forecaster's own chance of this, stated with the estimate: 85%); the middle value sits exactly at the limit.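

For the compounds shown here, compound 4 also gives only a limit, so no step from compound 1, compound 2 or compound 3 to compound 4 can be read: the limit of > 200000 nM in this assay, at which 4 of the 4 values shown sit. The compounds shown leave open how strongly each inhibits in this assay, and whether 2-methylphenyl and 3-methylphenyl differ at all.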